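Removing the Methyl from the Chain Amine

A few compounds are considered here, and "the series" means these few. Any claim that something is new, unique, unknown or untested is made for them only; others in the source may bear on it.

Among the measured compounds shown here, in a functional assay on MIA PaCa-2 cells (Homo sapiens) for inhibition, read by MTT assay, with a stated time of 72 h (a lower number here means a stronger inhibitor of growth, a higher number a weaker inhibitor of growth), compound 2 `CN(CCCNS(=O)(=O)c1cc(C(F)(F)F)cc(C(F)(F)F)c1)Cc1ccccc1` gives 33000 nM, the highest of the two numbers measured so far. For the measured compounds named here, its only neighbour, compound 1 `COc1cccc(CNCCCNS(=O)(=O)c2cc(C(F)(F)F)cc(C(F)(F)F)c2)c1`, gives 3400 nM, and the step of a 9.7-fold higher number from compound 1 to compound 2 (0.99 log units; beyond the scatter) is the single measured step; it bundles two changes at once, the chain amine gaining a methyl and the ring losing its methoxy group.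

Compound 3 `O=S(=O)(NCCCNCc1ccc(Br)cc1)c1cc(C(F)(F)F)cc(C(F)(F)F)c1` differs from compound 2 in one place: (4-bromobenzyl)amino in place of benzyl(methyl)amino on a saturated chain carbon, three bonds along the chain from a sulfonamide nitrogen. The amine hydrogen that compound 1 carries comes back, while the ring now bears a bromine where compound 1 has a methoxy group. Going by the values given here, only the step from compound 1 to compound 2 bears on this, and it was modest; since it cannot be split between its two changes, the return of the amine hydrogen is expected to win back part, perhaps most, of that step, with the bromine an unknown.

Compound 3 is therefore expected to give a lower number, about 4500 nM, in the range 1500 nM to 14000 nM. That estimate means a 7.3-fold lower number from compound 2 to compound 3 (0.87 log units; beyond the scatter).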

Compound 3, concentration for 50% growth inhibition: 2300 nM
Compound 3: middle estimate off by 2.0-fold (0.29 log units), on the high side, and the stated range covers the measured number.
By their numbers in this assay, from the lowest: compounds 3 and 1 (each within the scatter of the next); then compound 2.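

Among the compounds shown here, the step of a 1.5-fold lower number from compound 1 to compound 3 (0.17 log units; within the scatter) is the first comparison in which the amine hydrogen stays in place and only the ring changes, and in this assay swapping 3-methoxyphenyl for 4-bromophenyl leaves the two numbers within the usual scatter. For the compounds shown here, the step of a 14-fold lower number from compound 2 to compound 3 (1.16 log units; beyond the scatter) is large, so compound 2, the one compound here with a methyl on the chain amine and also the one with an unsubstituted benzyl ring, stands apart from the two compounds that keep the amine hydrogen and carry a ring substituent, but this step still bundles the loss of the methyl with the gain of the bromine. Nothing available here explains why the numbers fall this way.

The compounds shown leave open which of those two differences sets compound 2 apart, a question that a plain benzyl group on an amine keeping its hydrogen, or a 4-bromobenzyl group on an amine carrying a methyl, would address directly. Also open, from the compounds shown here alone, is how this position would respond to an ethyl group on the amine nitrogen, or to a nitrile on the ring in place of the bromine or the methoxy group.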